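This account rests on a few compounds, and the source may have more. Where it says the series, first, only, none or still open, it means among the compounds named here.

Three compounds of a shared core have been examined in an assay on CHO cells for displacement of a labelled ligand from adenosine receptor A1 (Homo sapiens), read by scintillation counting, with a stated time of 90 min; on this read-out lower numbers stand for stronger inhibition and higher numbers for weaker inhibition. Compound 1 `Cc1ccc(-c2nc3c(N)nc(NCc4cccs4)nc3s2)o1` gives 71 nM. Compound 2 `COc1cccc(CNc2nc(N)c3nc(-c4cccs4)sc3n2)c1` gives 37 nM. Compound 3 `COc1ccccc1CNc1nc(N)c2nc(-c3ccc(C)o3)sc2n1` gives 29 nM, the lowest of the three numbers; its gap to compound 2 lies within the scatter, while the step of a 2.4-fold lower number from compound 1 to compound 3 (0.39 log units; beyond the scatter), a change of the aryl group on the saturated chain carbon bound to the ring nitrogen, is beyond it.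

Compound 4 `COc1ccccc1CNc1nc(N)c2nc(-c3cccs3)sc2n1` differs from compound 3 in a different place: thiophen-2-yl in place of 5-methylfuran-2-yl on an aromatic carbon. Among the measured compounds shown here, no measured step matches this exchange on the core. For the measured compounds named here, compound 1 and compound 2 carry the two groups in question, but they also differ in the benzylic part, so their values show only that both groups sit within a modest range of each other. On that basis no step beyond the scatter is expected; the estimated change a 1.1-fold higher number from compound 3 to compound 4 (0.04 log units; within the scatter) is small. Compound 4 is therefore expected to give about 32 nM, within a range of 13 nM to 80 nM.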

Compound 4, inhibition constant: 17.3 nM
Compound 4: the middle estimate sits 1.8-fold (0.27 log units) above what was measured, and the stated range covers the measured number.
By their numbers in this assay, from the lowest: compounds 4, 3, 2 and 1 (each within the scatter of the next, the first and the last beyond it).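

The direct exchange on the shared core, a 1.7-fold lower number from compound 3 to compound 4 (0.22 log units; within the scatter), shows that in this assay thiophen-2-yl and 5-methylfuran-2-yl on this aromatic carbon cannot be told apart when 2-methoxyphenyl is present. With thiophen-2-yl held constant, the chain carbon bound to a nitrogen on an aromatic ring responds to a change between two methoxyphenyl groups, a 2.1-fold lower number from compound 2 to compound 4 (0.33 log units; beyond the scatter), a modest step beyond the scatter that adds to the earlier gain over thiophen-2-yl at that place, a 2.4-fold lower number from compound 1 to compound 3 (0.39 log units; beyond the scatter). Nothing available explains either step.

The compounds shown leave open whether a phenyl ring or an amine on the aromatic carbon would stay within this narrow range. They also leave open how a longer chain in place of the methoxy group would read.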